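Aryl ether in place of benzyl on the shared core

The compounds below may be only part of what the source reports. "The series", "measured", "known", "first", "only" and "open" are said of these compounds alone.

Three compounds have numbers in an ADME assay on HepG2 cells (Homo sapiens) for cytotoxicity, read by luminescence, CellTiter-Glo and ATP content, with a stated time of 72 h; on this read-out higher numbers stand for an effect only at larger amounts of compound and lower numbers for an effect already at smaller amounts:
compound 1 `FC(F)(F)c1ccc(-c2ccc3c(NCCCNCc4ccco4)ccnc3c2)cc1` gives 3470 nM
compound 2 `Cc1cc(C)cc(Cc2ccc3c(NCCCNCc4ccco4)ccnc3c2)c1` gives 6270 nM
compound 3 `COc1cccc(CNCCCNc2ccnc3cc(Cc4cc(C)cc(C)c4)ccc23)c1O` gives 2680 nM

Compound 2 has the highest of the three numbers. Its nearest neighbour is compound 1, and the step of a 1.8-fold higher number from compound 1 to compound 2 (0.26 log units; within the scatter) lies within the scatter. Compound 3 is furthest away, and the step of a 2.3-fold lower number from compound 2 to compound 3 (0.37 log units; beyond the scatter) goes beyond the scatter, though only modestly.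

Compound 4 `CN(C)c1cccc(Oc2ccc3c(NCCCNCc4ccco4)ccnc3c2)c1` has not yet been measured. It differs from compound 2 in one place: 3-(dimethylamino)phenoxy in place of 3,5-dimethylbenzyl on an aromatic carbon. For the measured compounds named here, of the measured steps, only the one at the same aromatic carbon bears directly on this change, namely a 1.8-fold higher number from compound 1 to compound 2 (0.26 log units; within the scatter), which stayed within the scatter. The step of a 2.3-fold lower number from compound 2 to compound 3 (0.37 log units; beyond the scatter) concerns a different part of the molecule and says little here. Compound 4 is therefore expected to give a number close to that of compound 2, with no step beyond the scatter, and the estimate for compound 4 is 4500 nM, within a range from 1500 nM to 13000 nM. This estimate means the expected step of a 1.4-fold lower number from compound 2 to compound 4 (0.14 log units; within the scatter).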

Compound 4, half-maximal effective concentration: 16000 nM
The estimate for compound 4 lay 3.6-fold (0.55 log units) below the measured number; the measured number lies above the stated range.
By their numbers in this assay, from the lowest: compounds 3, 1 and 2 (each within the scatter of the next, the first and the last beyond it); then compound 4.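

At this aromatic carbon, the earlier exchange had stayed within the scatter in this assay, whereas 3-(dimethylamino)phenoxy in place of 3,5-dimethylbenzyl gives a 2.6-fold higher number from compound 2 to compound 4 (0.41 log units; beyond the scatter) and so shows that the number does respond to the group placed here, if only modestly. Set against 4-(trifluoromethyl)phenyl, the same group gives a 4.6-fold higher number from compound 1 to compound 4 (0.66 log units; beyond the scatter) and thus places 3-(dimethylamino)phenoxy beyond the scatter from both earlier groups at this carbon, on the side of an effect only at larger amounts of compound. No measurement at hand accounts for this shift.

On these data alone, it remains open whether the ether oxygen or the dimethylamino group carries the step, a question that a plain phenoxy group or a 3-(dimethylamino)benzyl group at this carbon would separate. Also open, as far as these compounds go, is whether the step would hold with the 2-hydroxy-3-methoxyphenyl group of compound 3 in place of furan-2-yl.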